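The source may report more compounds than this note shows. Statements on the series, on what has been measured and on what is new or still open speak of the compounds shown alone.

Measured in a functional assay (trachea) with Cavia porcellus as the target; on this read-out higher numbers stand for weaker inhibition and lower numbers for stronger inhibition:
- Compound 1 `CC(C)n1nc(-c2cccnc2)c2ccccc2c1=O`: 3090 nM
- Compound 2 `O=C(c1cccs1)n1nc(-c2cccnc2)c2ccccc2c1=O`: 12300 nM

Compound 2 holds the higher of the two numbers, so it is the weaker inhibitor. Compound 3 `O=c1c2ccccc2c(-c2cccnc2)nn1CCSc1nccs1` changes the same place: 2-((1,3-thiazol-2-yl)sulfanyl)ethyl in place of (thiophen-2-yl)carbonyl on an aromatic nitrogen. The carbonyl leaves, and compound 1 lacks one there too. Among the measured compounds shown here, the only measured step that bears on this is modest: a 4.0-fold higher number from compound 1 to compound 2 (0.60 log units; beyond the scatter). One step is thin evidence, but a partial reversal seems likely. The estimated change is a 2.7-fold lower number from compound 2 to compound 3 (0.44 log units; beyond the scatter). In this assay, compound 3 is expected near 4500 nM, with an estimated range of 1200 nM to 15000 nM.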

Compound 3, half-maximal inhibitory concentration: 10500 nM
Compound 3: the middle estimate sits 2.3-fold (0.37 log units) below what was measured, within the range that was stated.
By their numbers in this assay, from the lowest: compound 1; then compounds 3 and 2 (each within the scatter of the next).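

In this assay, putting 2-((1,3-thiazol-2-yl)sulfanyl)ethyl in place of (thiophen-2-yl)carbonyl gives a 1.2-fold lower number from compound 2 to compound 3 (0.07 log units; within the scatter), so losing the carbonyl does not recover the number of compound 1. The same group, set against isopropyl, gives a 3.4-fold higher number from compound 1 to compound 3 (0.53 log units; beyond the scatter), which leaves both groups bearing a five-membered aromatic ring on the weaker side of isopropyl. Nothing measured here explains this. Still open, as far as these compounds go, is whether a plain longer chain with no ring, or an amine at the end of such a chain, would match isopropyl. Also open, from the compounds shown here alone, is whether the ring or the sulfanyl link sets the number of compound 3.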